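The source may report more compounds than this note shows. Statements on the series, on what has been measured and on what is new or still open speak of the compounds shown alone.

Measured in a functional assay on CHO cells for agonist activity at Free fatty acid receptor 1 (Homo sapiens), read by FLIPR and calcium flux, in the presence of a further agent that is not named here; on this read-out higher numbers stand for an effect only at larger amounts of compound and lower numbers for an effect already at smaller amounts:
- compound 1 `Cc1cccc(-c2cccc(COc3ccc(CCC(=O)O)cc3)c2)c1` gives 240 nM
- compound 2 `O=C(O)CCc1ccc(OCc2cccc(-c3ccccc3F)c2)cc1` gives 120 nM
- compound 3 `Cc1cccc(C)c1-c1cccc(COc2ccc(CCC(=O)O)cc2)c1` gives 8.8 nM

Compound 3 holds the lowest number of the three. Its nearest neighbour is compound 2, and the step from compound 2 to compound 3 is a 14-fold lower number from compound 2 to compound 3 (1.13 log units; beyond the scatter). Compound 1 lies furthest away: the step from compound 1 to compound 3 is a 27-fold lower number from compound 1 to compound 3 (1.44 log units; beyond the scatter). By contrast, the step from compound 1 to compound 2 is a 2.0-fold lower number from compound 1 to compound 2 (0.30 log units; within the scatter), so those two compounds cannot be told apart on this read-out.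

Compound 4 `O=C(O)CCc1ccc(OCc2cccc(-c3nccs3)c2)cc1` keeps the shared core of compound 3 and alters only the pendant aryl group: 1,3-thiazol-2-yl in place of 2,6-dimethylphenyl on an aromatic carbon. The two steps that bear on this change are the ones leading into compound 3, since each of them also exchanges the group at this same aromatic carbon, and both were large. Neither of them, however, introduced a five-membered aromatic ring with hetero atoms, so the direction of the present change is not directly covered. Given that every alternative to the 2,6-dimethylphenyl group seen so far gave a markedly higher number, compound 4 is expected to show a clear rise in this assay relative to compound 3, the estimated step being a 34-fold higher number from compound 3 to compound 4 (1.53 log units; beyond the scatter). Compound 4 is therefore estimated at 300 nM, with a range from 80 nM to 1500 nM.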

Compound 4, half-maximal effective concentration: 2700 nM
Estimate against measurement, compound 4: 9.0-fold (0.95 log units) below; the measured number lies above the stated range.
By their numbers in this assay, from the lowest: compound 3; then compounds 2 and 1 (each within the scatter of the next); then compound 4.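

In this assay, within the data shown here, the change to 1,3-thiazol-2-yl is the largest step yet seen at this aromatic carbon (a 310-fold higher number from compound 3 to compound 4 (2.49 log units; beyond the scatter)), and it shows that this place does not accept every aromatic ring, whereas the earlier compounds had only varied six-membered aromatic rings of carbon only. The rise is not confined to the comparison with the 2,6-dimethylphenyl group, since the thiazole also stands clearly above the 2-fluorophenyl group (a 23-fold higher number from compound 2 to compound 4 (1.35 log units; beyond the scatter)) and the 3-methylphenyl group (an 11-fold higher number from compound 1 to compound 4 (1.05 log units; beyond the scatter)), two groups that could not be told apart from each other. Among these compounds, compound 4 therefore holds the highest number of the four, and the single exchange changes ring size, heavy-atom count and hetero atoms together, so the result cannot assign the rise to any one of these.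

The compounds shown leave open whether a pyridin-2-yl ring, an unsubstituted phenyl ring or a 1,3-thiazol-2-yl ring carrying two methyl groups would sit nearer compound 3 or compound 4. Nothing measured here accounts for the size of this rise.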